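Chloro for Fluoro in a Level Series

The source may hold more compounds than are shown below. What is called first, only, known or untested is meant among the compounds shown, and "the series" means these compounds.

In a functional assay on DU-145 cells (Homo sapiens) for cytotoxicity, read by trypan blue exclusion, with a stated time of 96 h (on this read-out lower numbers stand for stronger inhibition and higher numbers for weaker inhibition), compound 1 `COc1cc(OC)c(/C=C/S(=O)(=O)Cc2ccc(OC)c(NC(F)(F)C(=O)O)c2)c(OC)c1` reads 150 nM and compound 2 `COc1cc(OC)c(/C=C/S(=O)(=O)Cc2ccc(OC)c(NC(C)(C)C(=O)O)c2)c(OC)c1` reads 150 nM while compound 3 `COc1cc(OC)c(/C=C/S(=O)(=O)Cc2ccc(OC)c(NC(C(=O)O)c3ccc(F)cc3)c2)c(OC)c1` reads 150 nM as well, so compound 3 stands level with both of the others. Within the data shown here, the next compound is compound 4 `COc1cc(OC)c(/C=C/S(=O)(=O)Cc2ccc(OC)c(NC(C(=O)O)c3ccc(Cl)cc3)c2)c(OC)c1` and its one difference from compound 3 is chloro in place of fluoro on an aromatic carbon with chloro in place of fluoro on an aromatic carbon, which turns 4-fluorophenyl into 4-chlorophenyl. Among the measured compounds shown here, no measured step makes this exact swap, so the evidence is indirect. Three measured steps exchange the whole group on the nitrogen and show no change at the digits printed from compound 1 to compound 2 (within the scatter) and no change at the digits printed from compound 1 to compound 3 (within the scatter) and no change at the digits printed from compound 2 to compound 3 (within the scatter) in turn. None of them leaves the scatter, and they give no direction to carry over. The halogen swap is therefore expected to give no change at the digits printed from compound 3 to compound 4 (within the scatter) with neither direction favoured. Compound 4 is estimated at 150 nM with 75 nM as the lower end and 300 nM as the upper end of the expected range.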

Compound 4, half-maximal inhibitory concentration: 400 nM
Compound 4: the middle estimate sits 2.7-fold (0.43 log units) below what was measured; measured number above the stated range.
By their numbers in this assay, from the lowest: compounds 1, 2 and 3 (each within the scatter of the next); then compound 4.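

In this assay chloro in place of fluoro, on an aromatic carbon para to a large group, gives a 2.7-fold higher number from compound 3 to compound 4 (0.43 log units; beyond the scatter) and is the only single change shown here that leaves the scatter along with the two steps below. Among these compounds, the exchanges of the whole group on the nitrogen among the earlier compounds moved nothing at the digits printed, whereas compound 4 also separates from the others, with a 2.7-fold higher number from compound 2 to compound 4 (0.43 log units; beyond the scatter) and with a 2.7-fold higher number from compound 1 to compound 4 (0.43 log units; beyond the scatter) as well, so this position responds to a halogen swap even though the group as a whole had seemed free to vary. Nothing shown accounts for the shift.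

The compounds shown leave open whether bromo or methoxy at this place would follow chloro or stay level with fluoro. They also leave open whether a plain phenyl would read with the fluoro compound or apart from it.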